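The source may hold more compounds than are shown below. What is called first, only, known or untested is meant among the compounds shown, and "the series" means these compounds.

Three close relatives share one core and differ only in the aryl group attached to the sulfonyl sulfur. Compound 1 `COc1ccc(-c2cc(=O)c3c(OC)cc(OC)cc3n2S(=O)(=O)c2ccc([N+](=O)[O-])cc2)cc1` carries a 4-nitrophenyl there, and in a functional assay on SUP-B15 cells (Homo sapiens) for antiproliferative activity, with a stated time of 72 h (on this read-out higher numbers stand for an effect only at larger amounts of compound and lower numbers for an effect already at smaller amounts), compound 1 gives 17100 nM. Compound 2 `COc1ccc(-c2cc(=O)c3c(OC)cc(OC)cc3n2S(=O)(=O)c2ccc(C)c([N+](=O)[O-])c2)cc1` carries a 4-methyl-3-nitrophenyl; in this assay compound 2 reaches only a limit, > 51700 nM. Compound 3 `COc1ccc(-c2cc(=O)c3c(OC)cc(OC)cc3n2S(=O)(=O)c2cc(F)c(F)c(F)c2)cc1` carries a 3,4,5-trifluorophenyl; in this assay compound 3 likewise reaches only a limit, > 65500 nM. So compound 3 stands at the weak end of what was measured, with no number below that limit.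

The two readable steps both ran the same way: an at least 3.0-fold higher number from compound 1 to compound 2 (0.48 log units; beyond the scatter) and an at least 3.8-fold higher number from compound 1 to compound 3 (0.58 log units; beyond the scatter). The step that the two limits leave unreadable from compound 2 to compound 3.

Compound 4 `COc1ccc(-c2cc(=O)c3c(OC)cc(OC)cc3n2S(=O)(=O)c2c(F)c(F)c(F)c(F)c2F)cc1` is the next member: 2,3,4,5,6-pentafluorophenyl in place of 3,4,5-trifluorophenyl on a sulfonyl sulfur. Both measured changes away from the 4-nitrophenyl of compound 1 raised the number past a limit, and adding fluorine atoms to an already fluorinated ring is a further step along that line. It is therefore expected that compound 4 will again sit at or beyond a limit, with no step beyond the scatter, a step that the limit leaves unreadable from compound 3 to compound 4. The estimate for compound 4 is 70000 nM, within a range from 20000 nM to 250000 nM.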

Compound 4, half-maximal effective concentration: 4100 nM
Compound 4: middle estimate off by 17-fold (1.23 log units), on the high side; measured number below the stated range.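

The aryl group on the sulfonyl sulfur can also move the number down, not only up: in this assay, the 2,3,4,5,6-pentafluorophenyl gives an at least 15-fold lower number from compound 3 to compound 4 (1.20 log units; beyond the scatter), the opposite direction to the earlier changes. It also gives an at least 12-fold lower number from compound 2 to compound 4 (1.10 log units; beyond the scatter) and a 4.2-fold lower number from compound 1 to compound 4 (0.62 log units; beyond the scatter), which makes compound 4 the most active of the four, ahead even of the 4-nitrophenyl. The step from compound 3 gives only a minimum size, because compound 3 stops at a limit: the limit of > 65500 nM in this assay, at which 1 of the 4 values shown sits.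

Within the data shown here, only two fluorinated rings appear here, so it remains open how the number changes with the count of fluorine atoms between them. Also open, as far as these compounds go, is where a plain phenyl, or a phenyl carrying an amine or a carboxylic acid, would fall.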